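A bromo for chloro exchange at low dose

This account rests on a few compounds, and the source may have more. Where it says the series, first, only, none or still open, it means among the compounds named here.

compound 1 (`O=C(CCCCC1CCSS1)Nc1ccc(Br)cn1`): 9%
compound 2 (`O=C(CCCCC(S)CCS)Nc1ccc(Cl)cn1`): "not active" (no number reported)

In a functional assay on NCI-H460 cells (Homo sapiens) for inhibition, read by MTT assay, with a stated time of 24 h, tested at 0.1 ug/mL (a lower number here means less inhibition of growth, a higher number more inhibition of growth at the concentration tested), compound 2 is reported as "not active" (no number reported) and has no single number, so it cannot be placed on the scale. Compound 1, by contrast, reads 9% as a measured number. Compound 3 (`O=C(CCCCC(S)CCS)Nc1ccc(Br)cn1`) has not yet been measured. One structural change leads to it: bromo in place of chloro on an aromatic carbon. Within the data shown here, no measured pair shows what this exchange does, so any step remains an expectation. In this assay a step no larger than the usual scatter is expected, with neither direction favoured. Growth inhibition is expected to stay low, since compound 1 reaches only 9% in this test. Compound 3 is estimated at 10%, with an expected range from 0% to 30% in this test.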

Compound 3, percent growth inhibition at one concentration: 6.4%
Beside the measured number, compound 3's estimate is 3.6 percentage points above it, and the stated range covers the measured number.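

In this assay the open group with no ring, set in place of the five-membered non-aromatic ring while the bromo group stays on the aromatic carbon, gives a number 2.6 percentage points lower from compound 1 to compound 3 (within the scatter) and so leaves the two readings indistinguishable at this low dose. The bromo for chloro exchange itself cannot be read as a step, as compound 2 is recorded as "not active" (no number reported) and offers no number to set against compound 3. No measurement at hand accounts for these readings.

The compounds shown leave open whether the bromo and chloro compounds would separate at higher concentrations. They also leave open how an amine or a methoxy group on that same aromatic carbon, or a longer chain on the amide carbonyl, would read.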